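A Methoxy Added Where the Ring Was Bare

The source may report more compounds than this note shows. Statements on the series, on what has been measured and on what is new or still open speak of the compounds shown alone.

Of the compounds shown here, three built on one shared core have been tested in a functional assay on K562 cells (Homo sapiens) for antiproliferative activity, read by MTT assay, with a stated time of 24 h; a lower number here means a stronger inhibitor, a higher number a weaker inhibitor. Compound 2 `COc1ccc(C(=O)/C=C/c2ccccc2)c2c1C=CC(C)(C)O2` carries a plain phenyl ring. In this assay compound 2 reaches only the limit > 10000 nM, not a number. Compound 1 `COc1ccc(C(=O)/C=C/c2ccc(C(F)(F)F)cc2)c2c1C=CC(C)(C)O2` likewise stops at the limit > 10000 nM. Compound 3 `COc1ccc(C(=O)/C=C/c2cccc(C(F)(F)F)c2)c2c1C=CC(C)(C)O2` gives 7850 nM. The steps measured so far are a step that the two limits leave unreadable from compound 1 to compound 2 and an at least 1.2-fold lower number from compound 2 to compound 3 (0.10 log units; that floor lies within the scatter), and the picture is dominated by the limit of > 10000 nM in this assay, at which 2 of the 3 values shown sit.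

Compound 4 `COc1ccccc1/C=C/C(=O)c1ccc(OC)c2c1OC(C)(C)C=C2` differs from compound 2 by methoxy in place of hydrogen on an aromatic carbon. For the measured compounds named here, no measured step alters the ring in this way; the one readable step only nudged the number, and compound 1 stayed at the limit after a different ring change. The step expected in this assay is an at least 1.1-fold lower number from compound 2 to compound 4 (0.04 log units; that floor lies within the scatter), nothing beyond the scatter. Compound 4 is expected to give about 9000 nM, within 4000 nM to 20000 nM, and may well again report only a limit.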

Compound 4, half-maximal inhibitory concentration: > 10000 nM
Compound 4: no number, only a limit; the forecaster's own chance of this, stated with the estimate: 55%; middle value at least 1.1-fold (0.04 log units) from the limit.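

Compound 2 and compound 4 both stop at a limit rather than a number, so no step can be read between them: the limit of > 10000 nM in this assay, at which 3 of the 4 values shown sit. From the compounds shown here alone, whether changing phenyl to 2-methoxyphenyl moves the activity at all in this assay stays open.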